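Methylation of the Phenol in Two Stilbene-like Cores

The source may report more compounds than this note shows. Statements on the series, on what has been measured and on what is new or still open speak of the compounds shown alone.

Measured compounds:
compound 1, `COc1cc(/C=C\Cc2cc(O)c3ccsc3c2)cc(OC)c1OC`, 87 nM
compound 2, `COc1cc(/C=C\Cc2cc(O)c3ccoc3c2)cc(OC)c1OC`, 49 nM
compound 3, `COc1cc(/C=C\Cc2cc(OC)c3ccsc3c2)cc(OC)c1OC`, 8100 nM

In a functional assay on BMEC cells (Bos taurus) for antiproliferative activity (on this read-out higher numbers stand for weaker inhibition and lower numbers for stronger inhibition), compound 1 gives 87 nM and compound 2 gives 49 nM; these two numbers lie within the scatter of each other. The difference between the two cores is not broken down here. Compound 3 carries the change (methyl in place of hydrogen on an oxygen on an aromatic ring), and in this assay it gives 8100 nM, which is a 93-fold higher number from compound 1 to compound 3 (1.97 log units; beyond the scatter).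

Compound 4, `COc1cc(/C=C\Cc2cc(OC)c3ccoc3c2)cc(OC)c1OC`, is not yet measured. It differs from compound 2 by methyl in place of hydrogen on an oxygen on an aromatic ring, the same change at the same place. Among the measured compounds shown here, for compound 4 the step is expected to be a 92-fold higher number from compound 2 to compound 4 (1.96 log units; beyond the scatter), resting on the single earlier step of a 93-fold higher number from compound 1 to compound 3 (1.97 log units; beyond the scatter). Compound 4 is therefore estimated at 4500 nM, with a likely range from 1000 nM to 20000 nM.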

Compound 4, half-maximal inhibitory concentration: 7500 nM
For compound 4 the middle estimate is 1.7-fold (0.22 log units) below the measured one; the range from low to high includes it.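

In this assay, the change from hydroxy to methoxy again gives a 150-fold higher number from compound 2 to compound 4 (2.18 log units; beyond the scatter). Set beside the earlier step, the two agree: the same change on two cores in this assay, a 93-fold higher number (1.97 log units; beyond the scatter) from compound 1 to compound 3 and a 150-fold higher number (2.18 log units; beyond the scatter) from compound 2 to compound 4, 1.6-fold (0.22 log units) apart, within the scatter of two such steps. So in this assay the change carries from the core of compound 1 to the core of compound 2 with much the same large size, but two cores do not show that it would hold on any other core, and they do not show why the numbers rise.

The compounds shown leave open what an ethyl group or an acetyl group on that oxygen would give, and what an amine in place of the hydroxy group would give. They also leave open whether the step holds in any other assay.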